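The source may hold more compounds than are shown below. What is called first, only, known or untested is meant among the compounds shown, and "the series" means these compounds.

Compound 1 `Nc1sc(-c2ccc(Cl)cc2)c(-c2ccc(Cl)cc2)c1C(=O)NC1CCCCC1`: 7300 nM
Compound 2 `CC1CCN(C(=O)c2c(N)sc(-c3ccc(Cl)cc3)c2-c2ccc(Cl)cc2)CC1`: 5750 nM

Among the measured compounds shown here, in a functional assay on PC-3 cells (Homo sapiens) for inhibition, read by sulforhodamine B assay, with a stated time of 72 h (a higher number here means a weaker inhibitor, a lower number a stronger inhibitor), compound 1 gives 7300 nM, and its only measured neighbour, compound 2, lies within the scatter of it. Compound 3 `CC(C)CNC(=O)c1c(N)sc(-c2ccc(Cl)cc2)c1-c1ccc(Cl)cc1` has isobutyl in place of cyclohexyl on an amide-type nitrogen. For the measured compounds named here, one measured step bears on this change, a 1.3-fold lower number from compound 1 to compound 2 (0.10 log units; within the scatter), which also replaces the cyclohexylamino group of compound 1. A single step is thin evidence, but it leads to an expectation of little movement in either direction. The expected 1.1-fold higher number from compound 1 to compound 3 (0.04 log units; within the scatter) stays within the scatter. The estimate for compound 3 is 8000 nM, with an expected range of 4000 nM to 16000 nM.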

Compound 3, half-maximal inhibitory concentration: 13200 nM
Compound 3: middle estimate off by 1.7-fold (0.22 log units), on the low side, within the range that was stated.
By their numbers in this assay, from the lowest: compounds 2, 1 and 3 (each within the scatter of the next, the first and the last beyond it).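

In the assay on PC-3 cells, this assay, replacing cyclohexyl with isobutyl on the amide-type nitrogen gives a step that stays within the usual scatter (a 1.8-fold higher number from compound 1 to compound 3 (0.26 log units; within the scatter)), so an open chain can stand in for the ring with no change that can be told apart here. Isobutylamino in place of 4-methylpiperidin-1-yl gives the first gap among these compounds to pass the scatter, though only modestly (a 2.3-fold higher number from compound 2 to compound 3 (0.36 log units; beyond the scatter)). No measurement offers an explanation for either step. Still open, going by these compounds, is whether an amine or a carboxylic acid on this chain would shift the number.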